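Compound 2 gains a ((carboxymethyl)carbonyl)amino group

This account rests on a few compounds, and the source may have more. Where it says the series, first, only, none or still open, it means among the compounds named here.

For the measured compounds named here, in a physicochemical assay for lipophilicity, using the shake flask method (a lower number here means a more polar compound, a higher number a more lipophilic compound), compound 2 `C[C@H](Oc1cccc(C2CC2)n1)c1c(Cl)ccc(F)c1Cl` gives 4.9, the higher of the two numbers so far. Compound 1 `C[C@H](Oc1ccc(NC(=O)CC(N)=O)c(C2CC2)n1)c1c(Cl)ccc(F)c1Cl` gives 3.7. Compound 3 `C[C@H](Oc1ccc(NC(=O)CC(=O)O)c(C2CC2)n1)c1c(Cl)ccc(F)c1Cl` has yet to be measured. It differs from compound 2 by a single change to the shared core: ((carboxymethyl)carbonyl)amino in place of hydrogen on an aromatic carbon. Here ((carboxymethyl)carbonyl)amino takes the place of hydrogen on an aromatic carbon, ortho to a cyclopropyl group and two atoms from the ring nitrogen.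

Going by the values given here, one measured step bears on this change: a number 1.20 log units higher from compound 1 to compound 2 (beyond the scatter), a large step in which hydrogen replaces ((carbamoylmethyl)carbonyl)amino on an aromatic carbon. Read in reverse, that step points to a large fall in this assay when compound 2 gains the new chain. Among the compounds with values here, the chains of compound 1 and compound 3 differ at their ends, carbamoylmethyl against carboxymethyl, and no measured step covers that difference. A fall somewhat larger than the reversed step is expected, with wide uncertainty. The expected change is a number 2.70 log units lower from compound 2 to compound 3 (beyond the scatter). Compound 3 is estimated at 2.2, with an expected range from 1.3 to 3.2.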

Compound 3, distribution coefficient: 1.4
Compound 3: the middle estimate sits 0.80 log units above what was measured; the range from low to high includes it.
By their numbers in this assay, from the lowest: compound 3; then compound 1; then compound 2.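

At this position, the ((carboxymethyl)carbonyl)amino chain lowers the number in this assay by far more than the earlier step suggested for a chain of this kind: the result is a number 3.50 log units lower from compound 2 to compound 3 (beyond the scatter), whereas the chain ending in an amide gave a number 1.20 log units higher from compound 1 to compound 2 (beyond the scatter) when removed. For the compounds shown here, the new information lies at the chain end, not in the attachment to the aromatic carbon, since the single exchange of hydroxy for amino on a carbonyl carbon gives a number 2.30 log units lower from compound 1 to compound 3 (beyond the scatter), a larger shift than the one separating compound 1 from the unsubstituted compound 2. No measurement given here accounts for the size of this end-group effect, so the compounds establish the shift but not its origin.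

From the compounds shown here alone, it remains open whether a methyl ester or a primary amine at the chain end would fall closer to compound 1 or to compound 3 in this assay. A longer chain between the amide and the terminal group is equally untested in these compounds, as is the same chain on another aromatic carbon of the shared core, so nothing here shows whether the shift depends on chain length or on this position.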